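Substituted Benzamide Series: Aryl Variation and Receptor Binding

This account rests on a few compounds, and the source may have more. Where it says the series, first, only, none or still open, it means among the compounds named here.

Measured compounds:
Compound 1, `Cc1ccc(S(=O)(=O)NCc2ccc(CNC(=O)c3ccccc3Cl)cc2)cc1`: 10 nM
Compound 2, `Cc1ccc(S(=O)(=O)NCc2ccc(CNC(=O)c3ccccc3F)cc2)cc1`: 1000 nM
Compound 3, `Cc1ccc(S(=O)(=O)NCc2ccc(CNC(=O)c3cccc(F)c3)cc2)cc1`: 1 nM

In an assay on MDA-MB-231 cells for binding affinity to C-X-C chemokine receptor type 4 (Homo sapiens), read by immunofluorescence and microscopy, with stated times of 10 min and 30 min (on this read-out lower numbers stand for an effect already at smaller amounts and higher numbers for an effect only at larger amounts of compound), compound 3 gives the lowest of the three numbers; compound 1 is the nearest, and compound 2 the furthest. Compound 4, `Cc1ccc(C(=O)NCc2ccc(CNS(=O)(=O)c3ccc(C)cc3)cc2)cc1`, is not yet measured. Its change from compound 3 is 4-methylphenyl in place of 3-fluorophenyl on a carbonyl carbon. Among the measured compounds shown here, no measured step exchanges a fluorophenyl for a methylphenyl, so the bearing is indirect: the steps of a 10-fold lower number from compound 1 to compound 3 (1.00 log units; beyond the scatter) and a 1000-fold lower number from compound 2 to compound 3 (3.00 log units; beyond the scatter) show that altering the aryl group on the carbonyl carbon moves this assay by large amounts, and a 100-fold higher number from compound 1 to compound 2 (2.00 log units; beyond the scatter) shows the same for a single halogen swap. Compound 3 sits at the lowest number seen, so a higher number for compound 4 is expected, with wide uncertainty, giving an estimated step of a 30-fold higher number from compound 3 to compound 4 (1.48 log units; beyond the scatter). The expected value for compound 4 is 30 nM, within 3 nM to 300 nM.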

Compound 4, effective concentration (reported as EC, without a stated level of effect): 1000 nM
Beside the measured number, compound 4's estimate is 33-fold (1.52 log units) below it; the measured number lies above the stated range.
By their numbers in this assay, from the lowest: compound 3; then compound 1; then compounds 2 and 4 (each within the scatter of the next).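

In this assay, 4-methylphenyl on the carbonyl carbon gives a 1000-fold higher number from compound 3 to compound 4 (3.00 log units; beyond the scatter) and a 100-fold higher number from compound 1 to compound 4 (2.00 log units; beyond the scatter), so a group without halogen also falls far from the lowest numbers in this series. Set against 2-fluorophenyl, the same position gives no change at the digits printed from compound 2 to compound 4 (within the scatter), which places compound 2 and compound 4 together. The groups exchanged between compound 3 and compound 4 match in heavy atoms, donors, acceptors and charge, so those counts do not follow the step.

Nothing available explains these differences. Still open, as far as these compounds go, is how an aryl group carrying an amine or a carboxylic acid would read at this position.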